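This account rests on a few compounds, and the source may have more. Where it says the series, first, only, none or still open, it means among the compounds named here.

Three compounds built on one shared core were tested in a functional assay on A549 cells (Homo sapiens) for antiproliferative activity, read by MTT assay, with a stated time of 48 h; on this read-out lower numbers stand for stronger inhibition and higher numbers for weaker inhibition. Compound 1 `N#CC1=C(N)Oc2c(c3nc4ccccc4nc3c3ccccc23)C12C(=O)N(Cc1cnnn1-c1cccc(Cl)c1)c1ccccc12` gives 32600 nM in this assay. Compound 2 `CCOc1ccccc1-n1nncc1CN1C(=O)C2(C(C#N)=C(N)Oc3c2c2nc4ccccc4nc2c2ccccc32)c2ccccc21` carries 2-ethoxyphenyl in place of 3-chlorophenyl on an aromatic nitrogen; in this assay compound 2 reaches only a limit of the assay, > 50000 nM. That change amounts to an at least 1.5-fold higher number from compound 1 to compound 2 (0.18 log units; that floor lies within the scatter), so it is a weak compound becoming one no longer measurable as a number.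

Compound 3 `N#CC1=C(N)Oc2c(N)cc3nc4ccccc4nc3c2C12C(=O)N(Cc1cnnn1-c1ccc(Cl)cc1)c1ccccc12` carries an amino group on the core and 4-chlorophenyl on the aromatic nitrogen. In this assay compound 3 also reaches only a limit of the assay, > 50000 nM. Compound 3 thus stands at the limit of > 50000 nM in this assay, at which 2 of the 3 values shown sit, with no number of its own to compare.

Compound 4 `N#CC1=C(N)Oc2c(N)cc3nc4ccccc4nc3c2C12C(=O)N(Cc1cnnn1-c1ccc([N+](=O)[O-])cc1)c1ccccc12` differs from compound 3 by nitro in place of chloro on an aromatic carbon. No measured step in this set swaps nitro for chloro, or alters any group on that phenyl ring; the only step shown, the replacement on the aromatic nitrogen, sits at the floor of the scatter. With compound 3 at a limit of the assay, > 50000 nM, no step beyond the scatter is expected in this assay. Compound 4 is therefore expected to remain near 50000 nM, between 25000 nM and 100000 nM. The step expected is a number no higher from compound 3 to compound 4 (the limit leaves the size open), most likely reported again only as a limit.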

Compound 4, half-maximal inhibitory concentration: > 50000 nM
Compound 4: a limit, no number; the forecaster's own chance of this, stated with the estimate: 70%; the middle value sits exactly at the limit.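

In this assay compound 3 and compound 4 each give only a limit and no number, so no step can be read between them: the limit of > 50000 nM in this assay, at which 3 of the 4 values shown sit.

Going by these compounds, what stays open is whether 4-nitrophenyl in place of 4-chlorophenyl changes the activity at all, and how far past the limit either compound lies.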